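Carboxyphenyl swap on the hydroxy core: expected maximal response

A few compounds are considered here, and "the series" means these few. Any claim that something is new, unique, unknown or untested is made for them only; others in the source may bear on it.

Compound 1 `Cc1c(OCCCCOc2ccc(C(=O)O)c(Cl)c2)ccc(C(=O)CC(C)C)c1C` gives 33.1% in an assay on HEK293 cells for positive allosteric modulation of metabotropic glutamate receptor 2 (Rattus norvegicus), read by thallium flux, with a stated time of 2.5 min; on this read-out lower numbers stand for smaller maximal responses and higher numbers for larger maximal responses. Compound 2 `Cc1c(OCCCCOc2ccccc2C(=O)O)ccc(C(=O)CC(C)C)c1C` gives 76.2% in this assay, and compound 3 `Cc1c(OCCCCOc2ccc(C(=O)O)c(Cl)c2)ccc(C(=O)CC(C)C)c1O` gives 80.5% in this assay; these two values lie within the scatter of each other. The change 2-carboxyphenyl in place of 4-carboxy-3-chlorophenyl on an oxygen on a saturated carbon made a step of a number 43.1 percentage points higher from compound 1 to compound 2 (beyond the scatter). The two cores differ by hydroxy in place of methyl on an aromatic carbon, which made a step of a number 47.4 percentage points higher from compound 1 to compound 3 (beyond the scatter). Compound 4 `Cc1c(OCCCCOc2ccccc2C(=O)O)ccc(C(=O)CC(C)C)c1O` is not yet measured; it carries the same change, (2-carboxyphenyl in place of 4-carboxy-3-chlorophenyl on an oxygen on a saturated carbon), at a place described in identical words. Compound 3 already stands at 80.5% and compound 2 at 76.2%, so the earlier large step is not expected to repeat. The step from compound 3 to compound 4 is expected to be a number 1.5 percentage points higher from compound 3 to compound 4 (within the scatter). For compound 4 the expected value is 82%, from 62% to 100%.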

Compound 4, largest response reached (reported as percent of maximum), in percent of the reference or control that the assay uses: 92.4%
Compound 4: the middle estimate sits 10.4 percentage points below what was measured, and the stated range covers the measured number.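

In this assay, 2-carboxyphenyl in place of 4-carboxy-3-chlorophenyl still gives a higher maximal response on the hydroxy-bearing core, with a step of a number 11.9 percentage points higher from compound 3 to compound 4 (beyond the scatter), but the size of the step does not carry over between cores: the same change on two cores in this assay, a number 43.1 percentage points higher (beyond the scatter) from compound 1 to compound 2 and a number 11.9 percentage points higher (beyond the scatter) from compound 3 to compound 4, 31.2 percentage points apart, beyond the scatter of two such steps. Hydroxy in place of methyl likewise keeps its direction, with a step of a number 16.2 percentage points higher from compound 2 to compound 4 (beyond the scatter), while its size depends on the carboxyphenyl group present: the same change on two cores in this assay, a number 47.4 percentage points higher (beyond the scatter) from compound 1 to compound 3 and a number 16.2 percentage points higher (beyond the scatter) from compound 2 to compound 4, 31.2 percentage points apart, beyond the scatter of two such steps. Across these four compounds the direction of each change carries over and its size does not, and the data do not show what sets the size.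

The 2-carboxyphenyl swap alters both the chlorine and the place of the carboxylic acid, so a 4-carboxyphenyl group would be needed to separate the two. On these data alone, whether either change keeps its direction with an amino group in place of the hydroxy remains open.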